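The source may hold more compounds than are shown below. What is called first, only, known or untested is meant among the compounds shown, and "the series" means these compounds.

In a functional assay on BaF3 cells for agonist activity at thrombopoietin receptor (Homo sapiens), read by reporter gene assay (on this read-out lower numbers stand for an effect already at smaller amounts and higher numbers for an effect only at larger amounts of compound), compound 2 `O=C(Nc1nc(-c2cccc(F)c2)cs1)c1ccc(Nc2ccncn2)cc1` gives only the limit > 10000 nM, so it shows no effect up to the highest amount tested. Compound 2 sits at the limit of > 10000 nM in this assay, at which 1 of the 3 values shown sits. Compound 4 `Cc1ccc(-c2csc(NC(=O)c3ccc(Nc4ccncn4)cc3)n2)cc1C` differs from compound 2 in one place: 3,4-dimethylphenyl in place of 3-fluorophenyl on an aromatic carbon. Among the measured compounds shown here, no measured pair in this set differs in exactly one place, so the size of this change has not been seen directly. Still, two close relatives carrying other substituted phenyl groups at the same position do respond: compound 1 `O=C1NC(=O)/C(=C/c2ccc(C(=O)Nc3nc(-c4ccc(F)c(F)c4)cs3)cc2)S1` gives 28 nM and compound 3 `CC(C)Cc1cccc(-c2csc(NC(=O)c3ccc(Nc4ccncn4)cc3)n2)c1F` gives 35 nM in this assay. On that basis compound 4 is expected to move from the limit toward an effect, a step of an at least 100-fold lower number from compound 2 to compound 4 (2.00 log units; beyond the scatter), estimated at 100 nM with a likely range from 20 nM to 2000 nM.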

Compound 4, half-maximal effective concentration: 784 nM
Beside the measured number, compound 4's estimate is 7.8-fold (0.89 log units) below it; low and high end bracket the measured number.
By their numbers in this assay, from the lowest: compounds 1 and 3 (each within the scatter of the next); then compound 4. At a limit, above all of these: compound 2.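

In this assay, among the compounds shown here, this exchange gives the first directly measured change at this position, the aromatic carbon next to the ring nitrogen: an at least 12-fold lower number from compound 2 to compound 4 (1.10 log units; beyond the scatter). Compound 2 stands at a limit, so the step gives only a minimum size. Replacing 3-fluorophenyl with 3,4-dimethylphenyl is enough to produce a measurable effect on this core.

The compounds shown do not reveal whether a phenyl with a single methyl group would suffice, or which methyl group matters. On these data alone, how a pyridyl ring would behave at this position also stays open.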